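This account rests on a few compounds, and the source may have more. Where it says the series, first, only, none or still open, it means among the compounds named here.

In a functional assay on MDA-MB-231 cells (Homo sapiens) for antiproliferative activity, read by sulforhodamine B assay, with a stated time of 72 h (on this read-out lower numbers stand for stronger inhibition and higher numbers for weaker inhibition), compound 1 (`COc1cc2occ(-c3csc4ccccc34)c(=O)c2c(OC)c1OC`) gives 820 nM as its half-maximal inhibitory concentration. Compound 2 (`O=C(/C=C/c1csc2ccccc12)c1ccccc1O`) gives 5300 nM here, and compound 3 (`O=C(/C=C/c1csc2ccccc12)c1cc(F)ccc1O`) gives 8400 nM in the same test. Compound 3 therefore stands level with compound 2 within the scatter, at the high end of the three numbers and far from compound 1.

Compound 4 (`Cc1ccc(O)c(C(=O)/C=C/c2csc3ccccc23)c1`) has not yet been measured. It differs from compound 3 at a single place (methyl in place of fluoro on an aromatic carbon): methyl in place of fluoro on an aromatic carbon, para to a hydroxy group.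

Among the measured compounds shown here, only one measured step bears on this carbon, the exchange of hydrogen for fluoro, which gave a 1.6-fold higher number from compound 2 to compound 3 (0.20 log units; within the scatter) and so stayed within the scatter. For the measured compounds named here, no measured compound carries methyl at this carbon, so the data offer no direct reading of the new group. With hydrogen and fluoro at this carbon giving values within the scatter of each other, no step beyond the scatter is expected in this assay and no firm direction can be given. The expected step is small, at a 1.3-fold lower number from compound 3 to compound 4 (0.11 log units; within the scatter) and within the scatter. For compound 4 the estimate is 6500 nM with an expected range from 2800 nM to 15000 nM in this test.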

Compound 4, half-maximal inhibitory concentration: 6000 nM
Beside the measured number, compound 4's estimate is 1.1-fold (0.03 log units) above it, and the stated range covers the measured number.
By their numbers in this assay, from the lowest: compound 1; then compounds 2, 4 and 3 (each within the scatter of the next).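

In this assay the exchange of fluoro for methyl gives a 1.4-fold lower number from compound 3 to compound 4 (0.15 log units; within the scatter) and the exchange of hydrogen for methyl gives a 1.1-fold higher number from compound 2 to compound 4 (0.05 log units; within the scatter) on the same aromatic carbon. Where the earlier compounds allowed only hydrogen and fluoro to be set against each other at this carbon, para to a hydroxy group, there are now three groups, and compounds 2, 3 and 4 all lie within the scatter of one another, so the level reading is no longer confined to a single exchange. No measurement on hand accounts for this level reading.

As far as these compounds go, whether the reading stays level across this carbon for groups other than these three remains open, as a methoxy group, an amine, a carboxylic acid or a longer chain such as propyl could give a quite different number in this test. Also open, from the compounds shown here alone, is what the hydroxy group itself contributes to these numbers, and whether a methyl ether in its place would read the same.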